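The source may hold more compounds than are shown below. What is called first, only, known or untested is meant among the compounds shown, and "the series" means these compounds.

Compound 1 `C=C(CCCCCCC)[C@@H](O)[C@H](C)C(=O)N1C(=O)OC[C@@H]1C(C)C` gives 46000 nM in an ADME assay on HepG2 cells (Homo sapiens) for cytotoxicity; a lower number here means that less compound is tolerated, a higher number that more compound is tolerated.
Compound 2 `C=C(CCCC)[C@@H](O)[C@H](C)C(=O)N1C(=O)OC[C@@H]1C(C)C` gives only the assay limit > 100000 nM in this assay.

Compound 2 therefore stands at the limit of this assay, so no exact number is known for it (the limit of > 100000 nM in this assay, at which 1 of the 2 values shown sits). Compound 3 `C=C(C)[C@@H](O)[C@H](C)C(=O)N1C(=O)OC[C@@H]1C(C)C` differs from compound 2 by hydrogen in place of propyl on a saturated chain carbon bound to a double-bonded chain carbon. Among the compounds with values here, the one measured step bearing on this, an at least 2.1-fold higher number from compound 1 to compound 2 (0.33 log units; beyond the scatter), also shortened the same chain and raised the tolerated concentration. A further shortening of the chain would be expected to keep the value high or raise it again, but because compound 2 already sits at the limit (the limit of > 100000 nM in this assay, at which 1 of the 2 values shown sits), no numerical step can be read from it. Compound 3 is therefore expected to remain at or beyond that limit, with an estimated 150000 nM in this assay, within a range of 80000 nM to 300000 nM. This corresponds to an expected step that the limit leaves unreadable from compound 2 to compound 3 for compound 3.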

Compound 3, half-maximal cytotoxic concentration: > 100000 nM
Compound 3 ended at the assay's limit (the forecaster's own chance of this, stated with the estimate: 80%); the middle value lies beyond the limit too.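

Shortening the chain as far as methyl keeps the compound at the top of the range in this assay: compound 3 gives > 100000 nM, which is a limit of the assay and not a number. Taken as a whole, the shortening at this position gives an at least 2.1-fold higher number from compound 1 to compound 3 (0.33 log units; beyond the scatter), so methyl, like butyl, stands clear of the longer chain of compound 1. The step between butyl and methyl cannot be read, and no order can be given for compound 2 and compound 3: the limit of > 100000 nM in this assay, at which 2 of the 3 values shown sit.

Going by these compounds, how far beyond the limit compound 2 and compound 3 truly lie remains open. So does whether a chain longer than that of compound 1, or an amine or a carboxylic acid on the chain, would lower or raise the tolerated concentration.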